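A few compounds are considered here, and "the series" means these few. Any claim that something is new, unique, unknown or untested is made for them only; others in the source may bear on it.

Of the compounds shown here, three have been measured here, and a fourth is about to be. Compound 1 `Cc1cc(=O)n(-c2ccccc2OC(F)(F)F)nc1C(=O)Nc1ccc(Oc2ncnc3ccsc23)cc1` gives 25000 nM in a functional assay on HepG2 cells (Homo sapiens) for cytotoxicity, read by MTT assay, with a stated time of 72 h; a higher number here means a weaker inhibitor, a lower number a stronger inhibitor. Compound 2 `Cc1cc(=O)n(-c2ccccc2OC(F)(F)F)nc1C(=O)Nc1ccc(Oc2ncnc3ccsc23)c(F)c1` carries one change relative to compound 1, namely (fluoro in place of hydrogen on an aromatic carbon), and in this assay compound 2 gives 15700 nM; the step, a 1.6-fold lower number from compound 1 to compound 2 (0.20 log units; within the scatter), is small enough to count as no real movement. Compound 3 `Cc1cc(=O)n(-c2ccc(F)cc2)nc1C(=O)Nc1ccc(Oc2ncnc3sccc23)cc1` rests on a different core, and the difference between the two cores is not broken down here; in this assay compound 3 gives 6460 nM, the lowest of the three numbers, and its gaps to compound 2 and compound 1 both lie beyond the usual scatter.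

Compound 4 `Cc1cc(=O)n(-c2ccc(F)c(F)c2)nc1C(=O)Nc1ccc(Oc2ncnc3sccc23)cc1` is compound 3 with one added change: fluoro in place of hydrogen on an aromatic carbon. Among the measured compounds shown here, this is the same kind of change as the one from compound 1 to compound 2, though the surroundings differ: in compound 2 the new fluoro sits ortho to a large group, whereas in compound 4 it sits ortho to a fluoro group, and in both it sits meta to a large group. Because the earlier step of a 1.6-fold lower number from compound 1 to compound 2 (0.20 log units; within the scatter) stayed within the scatter, the expectation is that compound 4 also moves little from compound 3, and the step expected is a 1.3-fold lower number from compound 3 to compound 4 (0.11 log units; within the scatter). Compound 4 is therefore estimated at 5000 nM, with a likely range from 2500 nM to 12000 nM.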

Compound 4, half-maximal inhibitory concentration: 16800 nM
For compound 4 the middle estimate is 3.4-fold (0.53 log units) below the measured one; the whole stated range lies below it.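

In this assay, adding one fluoro to turn the 4-fluorophenyl group into a 3,4-difluorophenyl group gives a 2.6-fold higher number from compound 3 to compound 4 (0.42 log units; beyond the scatter), a modest shift towards weaker inhibition. The same kind of change therefore does not carry over unchanged from one core to the other, since the earlier step stayed within the scatter while this one moved beyond it, and the two steps differ by more than repeat measurements would explain: the same change on two cores in this assay, a 1.6-fold lower number (0.20 log units; within the scatter) from compound 1 to compound 2 and a 2.6-fold higher number (0.42 log units; beyond the scatter) from compound 3 to compound 4, 4.1-fold (0.62 log units) apart, beyond the scatter of two such steps. This does not show that the core is responsible, since the new fluoro also stands at a different place in the molecule in each pair, here ortho to a fluoro group, and a single pair on each core cannot separate these two differences or supply a general rule for the series.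

The compounds shown leave open whether the higher number for compound 4 is specific to fluoro or would also appear with a chloro, a methyl or a methoxy group in the same place. They also leave open how an amine or a carboxylic acid at that position would read in this assay.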